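A few compounds are considered here, and "the series" means these few. Any claim that something is new, unique, unknown or untested is made for them only; others in the source may bear on it.

Compound 3, with structure `NC(=O)CCn1nc(-c2ccccc2)ccc1=O`, stands lowest of the three numbers measured in a functional assay on the whole organism (stomach) for inhibition, with Rattus norvegicus as the target, at a dose of 100 mg/kg by the intraduodenal route; a lower number here means less inhibition, a higher number more inhibition at the dose given (going by the name of the read-out): compound 3 gives -2.8%. Its nearest neighbour, compound 2, with structure `C/N=C(\S)CCn1nc(-c2ccccc2)ccc1=O`, gives 68.2%, and the furthest, compound 1, with structure `N=C(S)CCCn1nc(-c2ccccc2)ccc1=O`, gives 75.6%. Compound 4, with structure `CC(CC(=N)S)n1nc(-c2ccccc2)ccc1=O`, is the unmeasured member, and it differs from compound 3 in one place: a group of 6 heavy atoms (4 carbon, 1 nitrogen, 1 sulfur; no ring) in place of a group of 5 heavy atoms (3 carbon, 1 nitrogen, 1 oxygen; no ring), on an aromatic nitrogen.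

Among the measured compounds shown here, two measured steps bear on this change, since both end at compound 3 and exchange a group holding sulfur and nitrogen for the carbamoyl group: a number 78.4 percentage points lower from compound 1 to compound 3 (beyond the scatter) and a number 71 percentage points lower from compound 2 to compound 3 (beyond the scatter). The step of a number 7.4 percentage points lower from compound 1 to compound 2 (within the scatter) shows that the two sulfur-bearing chains gave similar numbers in this assay. The change from compound 3 to compound 4 runs in the opposite direction to the two large steps, bringing a chain with sulfur and nitrogen back in place of the carbamoyl group, so a large rise is expected. For the measured compounds named here, because compound 1 gives 75.6% with a related chain, compound 4 is expected to land near that level, though its exact chain has no measured counterpart, so the range is wide. The expected step is a number 67.8 percentage points higher from compound 3 to compound 4 (beyond the scatter). The estimate for compound 4 is 65%, between 35% and 85%.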

Compound 4, a percentage reported as inhibition, in the whole organism at one dose (the size of the read-out at that dose, not a potency): 15.5%
For compound 4 the middle estimate is 49.5 percentage points above the measured one; measured number outside the range, below it.
By their numbers in this assay, from the lowest: compound 3; then compound 4; then compounds 2 and 1 (each within the scatter of the next).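

Putting the new chain on the aromatic nitrogen gives a number 18.3 percentage points higher from compound 3 to compound 4 (beyond the scatter) in this assay, so a chain ending in a group with sulfur and nitrogen does not by itself bring back the high numbers of the earlier sulfur-bearing compounds. The other two steps, a number 52.7 percentage points lower from compound 2 to compound 4 (beyond the scatter) and a number 60.1 percentage points lower from compound 1 to compound 4 (beyond the scatter), are both large, which shows that the form of the chain matters as well as its end group: the branched chain of compound 4 stands well apart from the unbranched chains of compound 1 and compound 2. No measurement at hand explains why this branched chain gives so much less inhibition at the dose tested.

The compounds shown do not separate the effect of the branch from that of the shorter main chain in compound 4, and a single methyl branch placed elsewhere on the chain of compound 1 would help to tell these apart. They also leave open how a carboxylic acid or an amine at the chain end would compare with the sulfur-bearing end group and the carbamoyl group.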